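This account rests on a few compounds, and the source may have more. Where it says the series, first, only, none or still open, it means among the compounds named here.

Of the compounds shown here, three sharing one core have been measured in a physicochemical assay for solubility, read by HPLC, with a stated time of 24 h; on this read-out higher numbers stand for higher solubility and lower numbers for lower solubility. Compound 1 `O=C1O[C@@H](CN2CCC(O)CC2)CN1c1ccc(-n2cc(-c3ccccn3)cn2)c(F)c1` gives 45900 nM, compound 2 `O=C1CSC(=O)N1C[C@H]1CN(c2ccc(-n3cc(-c4ccccn4)cn3)c(F)c2)C(=O)O1` gives 26900 nM, and compound 3 `CC(=O)OC[C@H]1CN(c2ccc(-n3cc(-c4ccccn4)cn3)c(F)c2)C(=O)O1` gives 373000 nM, the highest of the three numbers. 2,4-Dioxo-1,3-thiazolidin-3-yl in place of 4-hydroxypiperidin-1-yl gives a 1.7-fold lower number from compound 1 to compound 2 (0.23 log units; within the scatter). Acetoxy in place of these two groups gives an 8.1-fold higher number from compound 1 to compound 3 (0.91 log units; beyond the scatter) and a 14-fold higher number from compound 2 to compound 3 (1.14 log units; beyond the scatter).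

Compound 4 `COC[C@H]1CN(c2ccc(-n3cc(-c4ccccn4)cn3)c(F)c2)C(=O)O1` carries methyl in place of acetyl on an oxygen on a saturated carbon. Among the compounds with values here, no measured pair shows this exact change, so the evidence is indirect. The two acetoxy steps show only that this place can move the number well beyond the scatter. Compound 3 stands at the top with 373000 nM, so a modest step to a lower number is expected in this assay, with a wide range. The expected change is a 2.2-fold lower number from compound 3 to compound 4 (0.34 log units; beyond the scatter). For compound 4 the estimated value is 170000 nM, with an expected range of 50000 nM to 450000 nM.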

Compound 4, solubility: 36200 nM
Compound 4: the middle estimate sits 4.7-fold (0.67 log units) above what was measured; measured number below the stated range.
By their numbers in this assay, from the lowest: compounds 2, 4 and 1 (each within the scatter of the next); then compound 3.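

In this assay, within the data shown here, the change from acetyl to methyl on this oxygen is a large step on its own, a 10-fold lower number from compound 3 to compound 4 (1.01 log units; beyond the scatter), the first direct reading of a change at this oxygen. Methoxy shows no separation from the two other groups on this saturated chain carbon, with a 1.3-fold higher number from compound 2 to compound 4 (0.13 log units; within the scatter) and a 1.3-fold lower number from compound 1 to compound 4 (0.10 log units; within the scatter), so among the four compounds only compound 3 stands apart, although the three other groups differ widely in size and make-up. No supporting measurement bears on why acetoxy stands apart.

Open, as far as these compounds go, is whether the high number in this assay is specific to acetyl on this oxygen or extends to a longer acyl chain such as propanoyl. Also open, from the compounds shown here alone, is where a free hydroxyl, a carboxylic acid or a simple dimethylamino group on this chain carbon would fall.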